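Working notes on an amine-chain variation, compounds 2 and 3

A few compounds are considered here, and "the series" means these few. Any claim that something is new, unique, unknown or untested is made for them only; others in the source may bear on it.

Measured so far:
Compound 1 `CCC(CC)Nc1nc(C)nc2c(-c3c(C)cc(N(C)C)nc3C)c(C)nn12`: 25.6 nM
Compound 2 `CCCCN(CCC)c1nc(C)nc2c(-c3ccc(OC)nc3C)c(C)nn12`: 2.4 nM

Both were run in an assay on cell membranes for displacement of a labelled ligand from corticotropin-releasing factor receptor 1 (Rattus norvegicus); a lower number here means a stronger inhibitor, a higher number a weaker inhibitor. Compound 2 gives 2.4 nM there, the lowest of the two numbers; compound 1 gives 25.6 nM, and the gap between the two lies beyond the scatter. Compound 1 and compound 2 differ in more than one place, so nothing more than these two values can be read from the pair.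

Compound 3 `CCCN(CC1CC1)c1nc(C)nc2c(-c3ccc(OC)nc3C)c(C)nn12` is not yet measured. It differs from compound 2 by cyclopropyl in place of propyl on a saturated chain carbon bound to a nitrogen on an aromatic ring. Going by the values given here, no measured step of this kind exists in this set, so the expectation rests on compound 2 alone. The change keeps the same count of heavy atoms on the amine substituent, and a step of this size is expected to stay within the scatter, with no clear direction. Compound 3 is therefore estimated at 3 nM in this assay, range 1 nM to 9 nM, which means an expected step of a 1.3-fold higher number from compound 2 to compound 3 (0.10 log units; within the scatter).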

Compound 3, half-maximal inhibitory concentration: 1.6 nM
Compound 3: middle estimate off by 1.9-fold (0.27 log units), on the high side; the measured number falls inside the stated range.
By their numbers in this assay, from the lowest: compounds 3 and 2 (each within the scatter of the next); then compound 1.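

In this assay, the amine chain now has its first readable step: cyclopropyl in place of propyl on a saturated chain carbon bound to a nitrogen on an aromatic ring gives a 1.5-fold lower number from compound 2 to compound 3 (0.18 log units; within the scatter), which lies within the scatter. This position therefore accepts a three-membered carbon ring in place of the open propyl at the same heavy-atom count, with no change that can be told from repeat measurement. No supporting data bear on why the two compounds read alike.

The compounds shown leave open whether this holds for a cyclobutyl or phenyl group in the same place, or for a chain carrying an ether oxygen. They also leave open what replacing the propyl group shared by compound 2 and compound 3 would do.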